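A few compounds are considered here, and "the series" means these few. Any claim that something is new, unique, unknown or untested is made for them only; others in the source may bear on it.

Three compounds have a number in an assay for inhibition of Fatty-acid amide hydrolase 1 (Rattus norvegicus); a lower number here means a stronger inhibitor, a higher number a weaker inhibitor. Compound 1 `O=C(CCc1ccc(-c2ccccc2)cc1)c1ncc(-c2cccnc2)o1` gives 1.1 nM, the lowest of the three. Compound 2 `CNC(=O)c1cnc(C(=O)CCc2ccc(Oc3ccccc3)cc2)o1` gives 11 nM, and compound 3 `O=C(O)c1cccc(-c2cnc(C(=O)CCc3ccc(-c4ccc(CN5CCCCC5)cc4)cc3)o2)n1` gives 44 nM; both differ from compound 1 in more than one place, so only the values themselves can be compared, and both stand beyond the scatter from compound 1. The next compound, compound 4 `COC(=O)c1cccc(-c2cnc(C(=O)CCc3ccc(-c4ccccc4)cc3)o2)n1`, differs from compound 1 in one place: 6-(methoxycarbonyl)pyridin-2-yl in place of pyridin-3-yl on an aromatic carbon. Going by the values given here, no measured pair isolates this change. The 6-(methoxycarbonyl)pyridin-2-yl group is expected to be accommodated, so the step of a 1.1-fold higher number from compound 1 to compound 4 (0.04 log units; within the scatter) is expected to stay within the scatter, in no clear direction. Compound 4 is therefore estimated at 1.2 nM, with a range from 0.3 nM to 5 nM.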

Compound 4, inhibition constant: 1.2 nM
Estimate against measurement, compound 4: no gap at the digits printed; the measured number falls inside the stated range.
By their numbers in this assay, from the lowest: compounds 1 and 4 (each within the scatter of the next); then compound 2; then compound 3.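

In this assay, the only one-place pair shown gives a 1.1-fold higher number from compound 1 to compound 4 (0.04 log units; within the scatter), so the position next to the ring oxygen takes 6-(methoxycarbonyl)pyridin-2-yl in place of pyridin-3-yl with the values within the scatter of each other. The entering group brings 10 heavy atoms against 6 and 3 hydrogen-bond acceptors against 1, so this position accepts a larger group here. Nothing available explains this result. From the compounds shown here alone, it remains open whether a nitrile or a primary amine in place of the methoxycarbonyl would stay within the scatter of compound 4.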